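Heteroaryl in place of sec-butyl on the amide nitrogen

The compounds below may be only part of what the source reports. "The series", "measured", "known", "first", "only" and "open" are said of these compounds alone.

The series is followed in an assay on HEK293 cells for agonist activity at transient receptor potential cation channel subfamily M member 8 (Homo sapiens), read by fluorescence and calcium flux, with a stated time of 15 min; a lower number here means that less compound is needed, a higher number that more compound is needed for the effect. Compound 1, `CCC(C)N(Cc1cccs1)C(=O)COc1ccc(C)cc1`, gives 2000 nM in this assay, the highest number among the three measured compounds. Compound 2, `CCN(Cc1cccs1)C(=O)COc1ccc2c(c1)CCC2`, gives 0.8 nM in this assay, and compound 3, `CCN(Cc1cccs1)C(=O)COc1ccc2c(c1)COC2`, gives 61 nM in this assay; both lie far below compound 1, yet each differs from it in more than one place, so the two values only show where compound 1 stands, not what any single change did.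

The next compound, compound 4, `Cc1ccc(OCC(=O)N(Cc2cccs2)c2ccn[nH]2)cc1`, has not yet been measured. It differs from compound 1 as follows: 1H-pyrazol-5-yl in place of sec-butyl on an amide-type nitrogen. Going by the values given here, no measured pair shows this change, so the size of the step cannot be read from the data. Compound 4 is expected to lie close to compound 1, with a step from compound 1 to compound 4 of a 1.3-fold lower number from compound 1 to compound 4 (0.12 log units; within the scatter) in this assay, within or just beyond the scatter. The estimate for compound 4 is 1500 nM, within a range from 200 nM to 10000 nM.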

Compound 4, half-maximal effective concentration: 0.2 nM
The estimate for compound 4 lay 7500-fold (3.88 log units) above the measured number, outside the stated range (below it).
By their numbers in this assay, from the lowest: compound 4; then compound 2; then compound 3; then compound 1.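

On the amide-type nitrogen, 1H-pyrazol-5-yl in place of sec-butyl gives, in this assay, a 10000-fold lower number from compound 1 to compound 4 (4.00 log units; beyond the scatter). Going by these compounds alone, this is the first single change whose effect can be read, and it shows that this one position can by itself carry a very large step, which the earlier compounds, each differing from compound 1 in more than one place, could not show. The change brings in a five-membered aromatic ring with 2 hetero atoms, 1 hydrogen-bond donor and 1 hydrogen-bond acceptor, all at once, so this single pair cannot separate their contributions.

As far as these compounds go, whether a phenyl ring or an N-methylated pyrazole at this nitrogen would give a similar number remains open. Nothing available explains why the number falls so far.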